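Carbamate ester size in the hydroxyurea-type series

The source may report more compounds than this note shows. Statements on the series, on what has been measured and on what is new or still open speak of the compounds shown alone.

compound 1 `CCOC(=O)N(O)CCC#Cc1ccc(OCCCCN2CCN(C(c3ccc(F)cc3)c3ccc(F)cc3)CC2)cc1`: 72 nM in a functional assay on blood for inhibition of Polyunsaturated fatty acid 5-lipoxygenase (Homo sapiens); on this read-out higher numbers stand for weaker inhibition and lower numbers for stronger inhibition
compound 2 `CC(C)OC(=O)N(O)CCC#Cc1ccc(OCCCCN2CCN(C(c3ccc(F)cc3)c3ccc(F)cc3)CC2)cc1`: 102 nM in this assay

Compound 2 carries the higher of the two numbers in this assay; its gap to compound 1, a 1.4-fold higher number from compound 1 to compound 2 (0.15 log units; within the scatter), is within the scatter. Compound 3 `COC(=O)N(O)CCC#Cc1ccc(OCCCCN2CCN(C(c3ccc(F)cc3)c3ccc(F)cc3)CC2)cc1` differs from compound 2 by methyl in place of isopropyl on an oxygen next to a carbonyl group. For the measured compounds named here, the only measured step bearing on this ester, a 1.4-fold higher number from compound 1 to compound 2 (0.15 log units; within the scatter), did not rise above the scatter, so no step beyond the scatter is expected here in either direction. Compound 3 is therefore expected near 70 nM, with a range of 35 nM to 140 nM in this assay. This amounts to an expected 1.5-fold lower number from compound 2 to compound 3 (0.16 log units; within the scatter).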

Compound 3, half-maximal inhibitory concentration: 90 nM
Compound 3: middle estimate off by 1.3-fold (0.11 log units), on the low side, and the stated range covers the measured number.
By their numbers in this assay, from the lowest: compounds 1, 3 and 2 (each within the scatter of the next).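

In this assay, the ester position now holds methyl, as well as the two larger groups, without any step beyond the scatter: a 1.1-fold lower number from compound 2 to compound 3 (0.05 log units; within the scatter), and a 1.3-fold higher number from compound 1 to compound 3 (0.10 log units; within the scatter). Across these three compounds, the read-out therefore does not separate methoxy, ethoxy and isopropoxy on the carbonyl. No supporting measurement bears on this result. Still open, as far as these compounds go, is whether a longer chain or a phenyl group on this oxygen would stay within the scatter of these three compounds. From the compounds shown here alone, an amino group in place of the methoxy is equally open.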